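What removing one methyl may do to compound 3

A few compounds are considered here, and "the series" means these few. Any claim that something is new, unique, unknown or untested is made for them only; others in the source may bear on it.

Measured so far in a functional assay on Bel-7402 cells (Homo sapiens) for antiproliferative activity, read by MTT assay, with a stated time of 72 h; a lower number here means a stronger inhibitor, a higher number a weaker inhibitor:
- compound 1 `COc1cccc(CNCc2c(C(=O)O)n(Cc3ccc(C)cc3)c3ccccc23)c1` gives 21500 nM (a number)
- compound 2 `COc1ccc(Cn2c(C(=O)O)c(CNCc3cccc(OC)c3)c3ccccc32)cc1` gives 52900 nM (a number)
- compound 3 `COc1cccc(CNCc2c(C(=O)O)n(Cc3ccccc3F)c3cc(C)ccc23)c1` gives > 50000 nM (a limit)

On these data alone, compound 3 has no number, only a limit (> 50000 nM), so its true position is unknown. Compound 4 `COc1cccc(CNCc2c(C(=O)O)n(Cc3ccccc3F)c3ccccc23)c1` has not yet been measured. It differs from compound 3 by hydrogen in place of methyl on an aromatic carbon.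

Among the compounds with values here, no measured pair shows this exact change. Within the data shown here, the only measured step (a 2.5-fold higher number from compound 1 to compound 2 (0.39 log units; beyond the scatter)) puts methoxy in place of methyl on an aromatic carbon, so it bears on the question only loosely. That step is modest, though beyond the scatter. On this evidence, a modest change is expected in this assay, not a large one. Like compound 4, compound 1 (21500 nM) and compound 2 (52900 nM) lack the methyl in question, and both gave numbers, which tilts the expectation toward a lower number. The expected step is modest (an at least 1.4-fold lower number from compound 3 to compound 4 (0.15 log units; that floor lies within the scatter)), though compound 4 could still return only a limit. For compound 4 the estimated value is 35000 nM, with an expected range from 14000 nM to 70000 nM in this read-out.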

Compound 4, half-maximal inhibitory concentration: > 50000 nM
Compound 4 was reported as a limit; the forecaster's own chance of this, stated with the estimate: 30%; middle value at least 1.4-fold (0.15 log units) away from the limit.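

In this assay compound 4 gives > 50000 nM, which is a limit and not a number, so hydrogen in place of methyl on this aromatic carbon does not bring the compound off the limit that compound 3 also shows. Within the data shown here, the steps to compound 4 from compound 2 and from compound 3 cannot be read, but the step with 2-fluorophenyl in place of 4-methylphenyl on the saturated chain carbon bound to an aromatic nitrogen can: an at least 2.3-fold higher number from compound 1 to compound 4 (0.36 log units; beyond the scatter), beyond the scatter, and the first readable step at that chain carbon. For the methyl itself, the result stops at a shared limit, so any gain or loss from removing it lies out of sight: the limit of > 50000 nM in this assay, at which 2 of the 4 values shown sit.

On these data alone, how far compound 3 and compound 4 lie apart therefore stays open, as does whether the methyl has any effect when a 4-methylphenyl group, rather than 2-fluorophenyl, stands on the chain carbon. Also open, as far as these compounds go, is what a chlorine atom or an amine would do on this aromatic carbon in place of the methyl.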